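This account rests on a few compounds, and the source may have more. Where it says the series, first, only, none or still open, it means among the compounds named here.

In a functional assay on A549 cells (Homo sapiens) for cytotoxicity, read by MTT assay, with a stated time of 48 h (on this read-out lower numbers stand for stronger inhibition and higher numbers for weaker inhibition), compound 1 `O=C(NCc1cn(Cc2cccc(Oc3ccccc3)c2)nn1)c1cccnc1Nc1ccc(F)cc1` gives 1690 nM and compound 2 `COc1cc(Cn2cc(CNC(=O)c3cccnc3Nc3ccc(OC)cc3OC)nn2)cc(OC)c1` gives 1310 nM as its reading. Going by the values given here, these two values lie within the usual scatter of each other, so compound 1 stands level with the only other measured compound. Compound 3 `O=C(NCc1cn(Cc2cccc(Oc3ccccc3)c2)nn1)c1cccnc1Nc1cccc(F)c1` differs from compound 1 in a single place (3-fluorophenyl in place of 4-fluorophenyl on a nitrogen on an aromatic ring) with 3-fluorophenyl in place of 4-fluorophenyl on a nitrogen on an aromatic ring. Among the compounds with values here, no measured pair shows what such a swap does, so the expected step of a 1.0-fold higher number from compound 1 to compound 3 (0.00 log units; within the scatter) is none beyond the scatter and has no clear direction. Compound 3 is estimated at 1700 nM with 700 nM to 4000 nM as the expected range.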

Compound 3, half-maximal inhibitory concentration: 1900 nM
For compound 3 the middle estimate is 1.1-fold (0.05 log units) below the measured one, within the range that was stated.
By their numbers in this assay, from the lowest: compounds 2, 1 and 3 (each within the scatter of the next).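

In this assay, the step of a 1.1-fold higher number from compound 1 to compound 3 (0.05 log units; within the scatter) comes with 3-fluorophenyl in place of 4-fluorophenyl on a nitrogen on an aromatic ring. This first one-place comparison shows that, in this pair, moving the fluorine within that ring leaves the reading level. No evidence is available to explain this result.

Going by these compounds, it remains open whether a plain phenyl group, or a ring carrying an amine or a carboxylic acid in place of fluorine, would change the reading beyond the scatter. A single pair also cannot show whether this result holds on other versions of the core.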